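The source may report more compounds than this note shows. Statements on the series, on what has been measured and on what is new or still open speak of the compounds shown alone.

Working notes on the series, read in a functional assay on RD cells (Homo sapiens) for inhibition, read by luminescence and ATP content, with a stated time of 72 h; on this read-out lower numbers stand for higher toxicity in this test and higher numbers for lower toxicity in this test.

Compound 1 `CCCc1ccc(-c2ccc3ncc(C(=O)OCC)cc3c2)cc1` and compound 2 `CCCCc1ccc(-c2ccc3ncc(C(=O)OCC)cc3c2)cc1` share a core and differ by methyl in place of hydrogen on a saturated chain carbon, three bonds along the chain from an aromatic carbon. In this assay compound 1 reports only a limit, > 7400 nM. Compound 2 likewise sits at a limit in this assay, > 7400 nM. The step that the two limits leave unreadable from compound 1 to compound 2 therefore cannot be sized; both values rest at the limit of > 7400 nM in this assay, at which 2 of the 3 values shown sit.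

Compound 3 `CCCCc1ccc(-c2ccc3ncc(-c4noc(C)n4)cc3c2)cc1` differs from compound 2 in the group on the core: a step that the two limits leave unreadable from compound 2 to compound 3 is also unreadable, as compound 3 gives only a limit in this assay, > 2500 nM, which is the limit of > 2500 nM in this assay, at which 1 of the 3 values shown sits. The difference between the cores of compound 1 and compound 3 is not broken down here.

Compound 4 `CCCCc1ccc(-c2ccc3ncc(-c4noc(CC)n4)cc3c2)cc1` is not yet measured. It differs from compound 3 by methyl in place of hydrogen on a saturated chain carbon bound to an aromatic carbon. This is the same kind of change as from compound 1 to compound 2, but the place differs: there the methyl entered three bonds along the chain from an aromatic carbon, here on a saturated chain carbon bound to an aromatic carbon. For the measured compounds named here, since no measured step in this assay is readable, the expectation for compound 4 rests only on all three values being limits. Compound 4 is expected at 5000 nM in this assay, most likely again reported as a limit, spanning 2000 nM to 20000 nM. The expected step is a step that the limit leaves unreadable from compound 3 to compound 4.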

Compound 4, half-maximal cytotoxic concentration: > 7400 nM
Compound 4: no number, only a limit (the forecaster's own chance of this, stated with the estimate: 80%); middle value at least 1.4-fold (0.17 log units) from the limit.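

In this assay compound 4 reports only a limit, > 7400 nM. Compound 2 and compound 3 also sit at limits, so the steps from compound 3 to compound 4 and from compound 2 to compound 4 cannot be read. The compounds shown leave open whether either change to compound 4 alters toxicity in this test at all.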